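A few compounds are considered here, and "the series" means these few. Any claim that something is new, unique, unknown or untested is made for them only; others in the source may bear on it.

In an assay on isolated protein for inhibition of vascular endothelial growth factor receptor 1 (Homo sapiens), read by ELISA, with a stated time of 20 min, tested at 1 uM (a lower number here means less inhibition, a higher number more inhibition at the concentration tested (going by the name of the read-out)), compound 1, `COc1cc2ncnc(Nc3ccc(B(O)O)cc3)c2cc1OC`, gives 49%. Two related compounds return no single number in this assay: compound 2, `COCCOc1cc2ncnc(Nc3cccc(B(O)O)c3)c2cc1OCCOC`, gives "not active" (no number reported), and compound 3, `COCCOc1cc2ncnc(Nc3ccc(B(O)O)cc3)c2cc1OC`, gives "not active" (no number reported). Compound 3 therefore stands without a number on the inhibition scale, and one further entry, compound 2, stands the same way, so only compound 1 supplies a figure against which the set can be read.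

Compound 4, `COCCOc1cc2ncnc(Nc3ccc(B(O)O)cc3)c2cc1OCCOC`, is the compound to be measured next. It differs from compound 3 in one place: methoxymethyl in place of hydrogen on a saturated chain carbon bound to an oxygen on an aromatic ring. For the measured compounds named here, no step between two measured compounds is available for this change, so the expected size of the step in this assay rests on the standing of compound 3 alone. Since compound 3 returned no number, the step from compound 3 to compound 4 is expected to be small, with no clear direction beyond the scatter. Compound 4 is estimated to give 15%, within a range from 0% to 40%.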

Compound 4, a percentage reported as inhibition, at one concentration (the size of the read-out at that concentration, not a potency): 41%
For compound 4 the middle estimate is 26 percentage points below the measured one, and the stated range ends below it.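

For the compounds shown here, no step from compound 3 to compound 4 can be read, as compound 3 carries no single number in this assay. The compounds shown leave open how methoxymethyl in place of hydrogen at that chain carbon changes inhibition. No evidence bears on the result.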